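Swapping the Ether Substituent on a Pyrazolopyrimidine Kinase Inhibitor

The source may report more compounds than this note shows. Statements on the series, on what has been measured and on what is new or still open speak of the compounds shown alone.

Of the compounds shown here, two have been measured so far in an assay for inhibition of serine/threonine-protein kinase Sgk1 (Homo sapiens), with stated times of 30 min and 60 min, in the presence of a further agent that is not named here; on this read-out higher numbers stand for weaker inhibition and lower numbers for stronger inhibition. Compound 1, `CC(C)NC(=O)c1cc(-c2ccc(NS(=O)(=O)c3cccc(Cl)c3Cl)cc2)nc2[nH]ncc12`, gives 17600 nM in this assay. Compound 2, `Cc1n[nH]c2nc(-c3ccc(NS(=O)(=O)c4cc(Cl)ccc4F)cc3)nc(OCC3(CN)COC3)c12`, gives 1 nM and so stands at the lowest of the two numbers, far below compound 1, a gap beyond the scatter. Compound 3, `Cc1n[nH]c2nc(-c3ccc(NS(=O)(=O)c4cc(Cl)ccc4F)cc3)nc(OC3CCC(=O)CC3)c12`, has not yet been measured; it differs from compound 2 by 4-oxocyclohexyl in place of (3-(aminomethyl)oxetan-3-yl)methyl on an oxygen on an aromatic ring. For the measured compounds named here, no pair of measured compounds differs in just this one place, so there is no measured step to lean on. The new group carries no hydrogen-bond donor where the old one carried one, and the expectation is a modest weakening: the step from compound 2 to compound 3 is estimated as a 6.0-fold higher number from compound 2 to compound 3 (0.78 log units; beyond the scatter). Compound 3 is therefore expected to give 6 nM in this assay, within a range from 1 nM to 40 nM.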

Compound 3, half-maximal inhibitory concentration: 18 nM
Compound 3: the middle estimate sits 3.0-fold (0.48 log units) below what was measured, and the stated range covers the measured number.
By their numbers in this assay, from the lowest: compound 2; then compound 3; then compound 1.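

In this assay, putting 4-oxocyclohexyl in place of (3-(aminomethyl)oxetan-3-yl)methyl on the oxygen gives an 18-fold higher number from compound 2 to compound 3 (1.26 log units; beyond the scatter), so this position responds clearly to what it carries, even though the two groups have equal heavy-atom counts. The loss is not total: compound 3 still gives 18 nM, so a group with no hydrogen-bond donor at this position remains compatible with a low number. No measurement available here explains the step.

The change swaps the ring, the amine and the ring oxygen in one move, so the compounds shown leave open which of these differences accounts for the step. A 4-aminocyclohexyl group would keep the six-membered carbon ring while restoring an amine, and a 4-hydroxycyclohexyl group would test an alcohol there instead.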